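The source may report more compounds than this note shows. Statements on the series, on what has been measured and on what is new or still open speak of the compounds shown alone.

Measured so far:
compound 1 `O=C(Nc1ccc(S(=O)(=O)NCc2ccccc2)cc1)c1ccc(Cl)cc1Cl`: "not determined" (no result reported)
compound 2 `O=C(Nc1ccc(S(=O)(=O)Nc2ccccc2)cc1)c1cc(F)c(Cl)cc1F`: 37%

Compound 1 `O=C(Nc1ccc(S(=O)(=O)NCc2ccccc2)cc1)c1ccc(Cl)cc1Cl` has no single number in a functional assay on HEK293 cells for agonist activity at probable G-protein coupled receptor 27 (Homo sapiens), read by a luciferase reporter and beta-arrestin recruitment, with a stated time of 10 min; on this read-out lower numbers stand for smaller maximal responses and higher numbers for larger maximal responses; its entry reads "not determined" (no result reported), so there is no starting value to stand on. Compound 2 `O=C(Nc1ccc(S(=O)(=O)Nc2ccccc2)cc1)c1cc(F)c(Cl)cc1F` differs from compound 1 in several places. In this assay compound 2 gives 37%, a modest maximal response. Among the measured compounds shown here, no step between these two is counted, and their values say only that one has a number and the other does not.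

Compound 3 `O=C(Nc1ccc(S(=O)(=O)Nc2ccccc2Cl)cc1)c1ccc(Cl)cc1Cl` differs from compound 1 in one place: 2-chlorophenyl in place of benzyl on a sulfonamide nitrogen. Cut one bond further out, the change reads benzylamino to (2-chlorophenyl)amino. With no number for compound 1, the size and direction of the step in this assay cannot be anticipated; no change beyond the usual scatter is assumed in either direction. Compound 3 is estimated to reach about 38% in this assay, within a range from 15% to 65%.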

Compound 3, largest response reached (Emax), in percent of the reference or control that the assay uses: 53%
Estimate against measurement, compound 3: 15 percentage points below; the measured number falls inside the stated range.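

In this assay compound 3 gives 53% and compound 1 has the entry "not determined" (no result reported) and no number, so no step can be read between them. As far as these compounds go, what replacing benzyl with 2-chlorophenyl does to the maximal response stays open, and no measured evidence bears on this result.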